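A few compounds are considered here, and "the series" means these few. Any claim that something is new, unique, unknown or untested is made for them only; others in the source may bear on it.

Measured compounds:
- compound 1, `CCN(Cc1ccccc1)c1cccc(C(=O)N2CCc3ccc(OS(N)(=O)=O)cc3C2)c1`: 17.3%
- compound 2, `CCN(Cc1ccc(F)cc1)c1cccc(C(=O)N2CCc3ccc(OS(N)(=O)=O)cc3C2)c1`: 10.9%
- compound 3, `CCCN(Cc1ccccc1)c1cccc(C(=O)N2CCc3ccc(OS(N)(=O)=O)cc3C2)c1`: 23.1%

All three share one core and differ only in the amino group on the outer aromatic ring. In an assay on HEK293 cells for inhibition of Steryl-sulfatase (Homo sapiens), tested at 0.1 uM (on this read-out higher numbers stand for a stronger effect at the one concentration tested and lower numbers for a weaker effect), compound 3 gives the highest of the three numbers, but the gap from compound 1 is small a number 5.8 percentage points higher from compound 1 to compound 3 (within the scatter), while the gap from compound 2 is beyond the scatter a number 12.2 percentage points higher from compound 2 to compound 3 (beyond the scatter).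

Compound 4, `CCCN(CCC)c1cccc(C(=O)N2CCc3ccc(OS(N)(=O)=O)cc3C2)c1`, has not yet been tested. It differs from compound 3 in one place: ethyl in place of phenyl on a saturated chain carbon bound to a nitrogen on an aromatic ring. In other words the benzyl becomes a propyl, so benzyl(propyl)amino turns into dipropylamino.

Among the measured compounds shown here, none of the measured steps removes a phenyl. The nearest comparisons are the fluoro added on that phenyl a number 6.4 percentage points lower from compound 1 to compound 2 (within the scatter) and the methyl added on the chain a number 5.8 percentage points higher from compound 1 to compound 3 (within the scatter), both within the scatter. For the measured compounds named here, the change to compound 4 is larger, and no measured step shows its effect directly, so the expected step of a number 6.1 percentage points lower from compound 3 to compound 4 (within the scatter) is none beyond the scatter. Compound 4 is therefore estimated at 17%, with a range from 5% to 30%.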

Compound 4, a percentage reported as inhibition, at one concentration (the size of the read-out at that concentration, not a potency): 8.3%
Beside the measured number, compound 4's estimate is 8.7 percentage points above it; low and high end bracket the measured number.
By their numbers in this assay, from the lowest: compounds 4, 2, 1 and 3 (each within the scatter of the next, the first and the last beyond it).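

Among the compounds shown here, replacing the phenyl with ethyl, which turns benzyl(propyl)amino into dipropylamino, gives in this assay a number 14.8 percentage points lower from compound 3 to compound 4 (beyond the scatter), the one step here that takes the aromatic ring away rather than altering the groups around it, and it is beyond the scatter. The same dipropylamino group reached from the other two amines gives a number 2.6 percentage points lower from compound 2 to compound 4 (within the scatter) and a number 9 percentage points lower from compound 1 to compound 4 (within the scatter), so losing the ring is clearly visible against only one of the three benzyl compounds. Nothing measured here explains the size of this step.

The compounds shown leave open whether the aromatic ring itself matters or just the six carbons it brings. A cyclohexyl in place of the phenyl, or a longer chain such as hexyl on that nitrogen, would help separate the two.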